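Side-chain acetoxy analogue: expected antiproliferative read-out

A few compounds are considered here, and "the series" means these few. Any claim that something is new, unique, unknown or untested is made for them only; others in the source may bear on it.

Compound 2 `COc1nc(C)c(CCF)c(OC)n1` is the reference point of this note. In a functional assay on SW-620 cells (Homo sapiens) for antiproliferative activity, read by MTT assay, with a stated time of 24 h (on this read-out lower numbers stand for stronger inhibition and higher numbers for weaker inhibition), compound 2 gives only a limit, > 100000 nM. Compound 1 `COc1nc(C)c(CCO)c(OC)n1` likewise reaches only a limit, > 100000 nM. Compound 3 `COc1nc(Cl)nc(C)c1CCF` also ends at a limit, > 100000 nM. Going by the values given here, the steps a step that the two limits leave unreadable from compound 1 to compound 2 and a step that the two limits leave unreadable from compound 2 to compound 3 thus carry no readable size, and the sole evidence on the measured steps is the limit of > 100000 nM in this assay, at which 3 of the 3 values shown sit. Compound 4 `COc1nc(C)c(CCOC(C)=O)c(OC)n1` differs from compound 2 by acetoxy in place of fluoro on a saturated chain carbon, two bonds along the chain from an aromatic carbon. Among the compounds with values here, no measured step gives a readable size that bears on this change, so no step beyond the scatter in either direction can be expected, and the most likely outcome is that compound 4 again sits at the limit. Compound 4 is therefore estimated at 150000 nM with a range from 50000 nM to 500000 nM. The expected step that the limit leaves unreadable from compound 2 to compound 4 amounts to no change.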

Compound 4, half-maximal inhibitory concentration: 44000 nM
Compound 4: the middle estimate sits 3.4-fold (0.53 log units) above what was measured, outside the stated range (below it).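

In this assay, acetoxy in place of fluoro on this saturated chain carbon gives an at least 2.2-fold lower number from compound 2 to compound 4 (0.35 log units; beyond the scatter). Acetyl in place of hydrogen on the oxygen of compound 1 gives an at least 2.2-fold lower number from compound 1 to compound 4 (0.35 log units; beyond the scatter), so the number at this position can move with the group carried there, and both sizes are lower bounds. The earlier steps cannot be read, and compound 4 alone gives a readable number: the limit of > 100000 nM in this assay, at which 3 of the 4 values shown sit.

From the compounds shown here alone, whether a longer ester, such as propionyloxy, or an acetamido group at this position would lower the number further stays open. Also open, going by these compounds, is how acetoxy would read with chloro in place of methoxy on the aromatic carbon.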